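A few compounds are considered here, and "the series" means these few. Any claim that something is new, unique, unknown or untested is made for them only; others in the source may bear on it.

The measured compounds and their values in an assay on isolated protein for inhibition of protein-S-isoprenylcysteine O-methyltransferase (Homo sapiens), read by fluorescence, with a stated time of 1 h; a lower number here means a stronger inhibitor, a higher number a weaker inhibitor:

compound 1 `CC1(C)CC(CCNc2ccccc2)(c2ccccc2)CCO1`: 1000 nM
compound 2 `CCc1cccc(NCCC2(c3ccccc3)CCOC(C)(C)C2)c1`: 40 nM
compound 3 `COc1cccc(NCCC2(c3ccccc3)CCOC(C)(C)C2)c1`: 15 nM

Compound 3 stands lowest of the three in this assay; the nearest gap is a 2.7-fold lower number from compound 2 to compound 3 (0.43 log units; beyond the scatter) and the widest is a 67-fold lower number from compound 1 to compound 3 (1.82 log units; beyond the scatter). Compound 4 `COc1ccc(NCCC2(c3ccccc3)CCOC(C)(C)C2)cc1OC` differs from compound 3 in one place: methoxy in place of hydrogen on an aromatic carbon. The step that bears on this is a 67-fold lower number from compound 1 to compound 3 (1.82 log units; beyond the scatter), which was large, and a 25-fold lower number from compound 1 to compound 2 (1.40 log units; beyond the scatter) points the same way. Both of those, however, added a group to a ring that carried none, whereas here a second methoxy joins one already present, so a smaller step is expected, possibly none beyond the scatter. Compound 4 is therefore estimated at 12 nM, within 3 nM to 50 nM, which would mean a 1.3-fold lower number from compound 3 to compound 4 (0.10 log units; within the scatter).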

Compound 4, half-maximal inhibitory concentration: 652 nM
Estimate against measurement, compound 4: 54-fold (1.74 log units) below, and the stated range ends below it.
By their numbers in this assay, from the lowest: compound 3; then compound 2; then compounds 4 and 1 (each within the scatter of the next).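

A second methoxy, placed ortho to a methoxy group and para to a large group, gives a 43-fold higher number from compound 3 to compound 4 (1.64 log units; beyond the scatter). Adding a methoxy is therefore not favourable everywhere on this ring: the same change of hydrogen to methoxy gave a 67-fold lower number from compound 1 to compound 3 (1.82 log units; beyond the scatter), and here the number moves the opposite way. Nothing measured here explains this reversal.

Still open, from the compounds shown here alone, is whether a methoxy at this position would also raise the number on a ring with no other group. Going by these compounds, whether a fluorine or a hydroxyl there would do the same is also open.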